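Series notes: fluoro in place of methoxy, growth inhibition

This account rests on a few compounds, and the source may have more. Where it says the series, first, only, none or still open, it means among the compounds named here.

Two members of the series have been run in a toxicity assay on THP-1 cells (Homo sapiens) for cytotoxicity, read by MTT assay, with a stated time of 48 h; on this read-out higher numbers stand for weaker inhibition of growth and lower numbers for stronger inhibition of growth. Compound 1, `O=C1NC(=S)S/C1=C\c1cc2cc(Cl)ccc2nc1Cl`, gives only a limit of the assay in this assay, namely > 100 ug/mL. Compound 2, `COc1ccc2nc(Cl)c(/C=C3\SC(=S)NC3=O)cc2c1`, likewise reaches only a limit in this assay, namely > 100 ug/mL. Among the measured compounds shown here, the single step available, methoxy in place of chloro on an aromatic carbon, is a step that the two limits leave unreadable from compound 1 to compound 2; its size cannot be read because both ends sit at the limit of > 100 ug/mL in this assay, at which 2 of the 2 values shown sit. For the measured compounds named here, compound 2 therefore stands at a limit, not at a number, and no ranking within the pair is possible.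

The next member, compound 3, `O=C1NC(=S)S/C1=C\c1cc2cc(F)ccc2nc1Cl`, differs from compound 2 by fluoro in place of methoxy on an aromatic carbon. Going by the values given here, no measured step bears directly on this exchange, and the one step in hand is itself unreadable. With both values at the limit, the expected step is none beyond the scatter, and the change is estimated as a step that the limit leaves unreadable from compound 2 to compound 3. Compound 3 is therefore expected to give about 150 ug/mL in this assay, with a range from 60 ug/mL to 400 ug/mL, most likely reported again only as a limit.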

Compound 3, concentration for 50% growth inhibition: > 100 ug/mL
Compound 3 gave a limit, no number (the forecaster's own chance of this, stated with the estimate: 80%); the middle value lies beyond the limit too.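

No new step can be read among compound 1, compound 2 and compound 3 in this assay, since each gives only a limit and no number: the limit of > 100 ug/mL in this assay, at which 3 of the 3 values shown sit. The compounds shown leave open whether chloro, methoxy or fluoro on the shared core makes any difference to growth inhibition, and at what concentration any of the three would reach the read-out.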